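A few compounds are considered here, and "the series" means these few. Any claim that something is new, unique, unknown or untested is made for them only; others in the source may bear on it.

Of the compounds shown here, two have been measured in a functional assay for agonist activity at G protein-coupled receptor 88 (Homo sapiens), read by HTRF and cAMP accumulation; on this read-out lower numbers stand for an effect already at smaller amounts and higher numbers for an effect only at larger amounts of compound. Compound 1 `CC[C@H](C)[C@H](N)CN(C(=O)[C@@H]1C[C@H]1c1cncnc1)c1ccc(-c2ccccc2)cc1` gives 19000 nM in this assay. Compound 2 `CC(C)C[C@H](N)CN(C(=O)[C@@H]1C[C@H]1c1ccccc1)c1ccc(-c2cccs2)cc1` gives 1500 nM in this assay, the lowest of the two numbers; its nearest neighbour is compound 1, whose number is higher by a margin beyond the usual scatter. Among the measured compounds shown here, the two structures differ in several places at once, so no single step is isolated between them.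

Compound 3 `COc1cccc(-c2ccc(N(C[C@@H](N)CC(C)C)C(=O)[C@@H]3C[C@H]3c3ccccc3)cc2)c1` has not been measured. It differs from compound 2 in one place: 3-methoxyphenyl in place of thiophen-2-yl on an aromatic carbon. For the measured compounds named here, no measured pair shows this exchange, so the expectation rests on compound 2 alone, with 1500 nM as anchor. The expected step of a 1.3-fold lower number from compound 2 to compound 3 (0.10 log units; within the scatter) is small, in either direction or none beyond the scatter. For compound 3 the estimate is 1200 nM, within a range from 400 nM to 4000 nM.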

Compound 3, half-maximal effective concentration: 1100 nM
Beside the measured number, compound 3's estimate is 1.1-fold (0.04 log units) above it; the range from low to high includes it.
By their numbers in this assay, from the lowest: compounds 3 and 2 (each within the scatter of the next); then compound 1.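

At the aromatic carbon para to a large group, 3-methoxyphenyl in place of thiophen-2-yl gives a 1.4-fold lower number from compound 2 to compound 3 (0.13 log units; within the scatter) in this assay and so leaves the number within the scatter. This position therefore accepts a six-membered aromatic ring of carbon only as well as a five-membered aromatic ring with 1 hetero atom, even as the group grows from 5 heavy atoms to 8 heavy atoms, with 1 hydrogen-bond acceptor on each side. Nothing at hand explains why the two groups read alike.

As far as these compounds go, only groups with no net charge have been seen at this position, so it remains open whether an amine or a carboxylic acid on the outer ring would read the same. Also open, from the compounds shown here alone, is whether the methoxy group itself counts, and whether an ethoxy group would read alike.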